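Trimming a methyl from an acid-bearing side chain

This account rests on a few compounds, and the source may have more. Where it says the series, first, only, none or still open, it means among the compounds named here.

Measured so far:
- Compound 1, `O=C(O)Cn1nc(Cc2nc3cc(Cl)c(OCC(F)F)cc3[nH]2)c2ccccc2c1=O`: < 56.7 mL/min/kg in an ADME assay on microsomes from liver (Mus musculus) for metabolic stability; a higher number here means faster removal of the compound, a lower number slower removal
- Compound 2, `CC(C)(C(=O)O)c1nn(Cc2cn3cc(OCC4CC4)c(Cl)cc3n2)c2ccccc2c1=O`: < 63.4 mL/min/kg in this assay
- Compound 3, `COc1cc(OC)c(NC(=O)Cc2nn(CC(=O)O)c(=O)c3ccccc23)cc1Cl`: < 55 mL/min/kg in this assay

Each of these three values is a limit of the assay, not a number. For compound 1, the value < 56.7 mL/min/kg is such a limit (the limit of < 56.7 mL/min/kg in this assay, at which 1 of the 3 values shown sits). For compound 3, the value < 55 mL/min/kg is such a limit (the limit of < 55 mL/min/kg in this assay, at which 1 of the 3 values shown sits). For compound 2, the value < 63.4 mL/min/kg is likewise a limit (the limit of < 63.4 mL/min/kg in this assay, at which 1 of the 3 values shown sits), so compound 2 stands at a cap, with no finished number to compare against the other two.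

Compound 4, `CC(C(=O)O)c1nn(Cc2cn3cc(OCC4CC4)c(Cl)cc3n2)c2ccccc2c1=O`, has not yet been measured. It differs from compound 2 in one place: hydrogen in place of methyl on a saturated chain carbon bound to an aromatic carbon, a carbonyl carbon and a saturated chain carbon. Among the measured compounds shown here, no step between two measured compounds is known here, so there is no yardstick for this kind of change. The step from compound 2 to compound 4 in this assay is expected to be small, with no direction beyond the usual scatter.

The estimate for compound 4 is 40 mL/min/kg, within a range from 15 mL/min/kg to 90 mL/min/kg, which means an expected step that the limit leaves unreadable from compound 2 to compound 4.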

Compound 4, clearance: 80 mL/min/kg
For compound 4 the middle estimate is 2.0-fold (0.30 log units) below the measured one; measured number inside the range.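

Among the compounds shown here, compound 4 is the only one of the four compounds with a finished number in this assay, so this side chain now has a measured value rather than only a cap. Replacing methyl with hydrogen on this saturated chain carbon, the change from 1-carboxy-1-methylethyl to 1-carboxyethyl, gives an at least 1.2-fold higher number from compound 2 to compound 4 (0.10 log units; that floor lies within the scatter). That figure is only a floor, and the true size of the step stays unreadable because compound 2 has no finished number: the limit of < 63.4 mL/min/kg in this assay, at which 1 of the 4 values shown sits.

On these data alone, whether losing the methyl truly speeds removal therefore remains open, and a finished number for compound 2 would be needed to settle it. As far as these compounds go, how an ethyl group or a fluorine atom on this carbon would behave also remains unknown.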